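The compounds below may be only part of what the source reports. "The series", "measured", "known", "first", "only" and "open" are said of these compounds alone.

In a functional assay on MCF7 cells (Homo sapiens) for inhibition, read by MTT assay (a lower number here means a stronger inhibitor, a higher number a weaker inhibitor), compound 1 (`COc1cc2ncnc(Nc3ccc(NC(=O)c4ccc(F)cc4)cc3)c2cc1OC`) gives 27000 nM and compound 2 (`COc1cc2ncnc(Nc3ccc(NC(=O)c4ccc(Cl)cc4)cc3)c2cc1OC`) gives 30000 nM so compound 2 stands level with compound 1. Compound 3 (`COc1cc2ncnc(Nc3ccc(NC(=O)c4cccc(C(F)(F)F)c4)cc3)c2cc1OC`) carries 3-(trifluoromethyl)phenyl in place of 4-chlorophenyl on a carbonyl carbon. Among the measured compounds shown here, the one measured step that bears on this is a 1.1-fold higher number from compound 1 to compound 2 (0.05 log units; within the scatter) and it lies within the scatter. It covers only chloro in place of fluoro on an aromatic carbon, so no step beyond the scatter is expected in this assay here. The expected step is a 1.1-fold lower number from compound 2 to compound 3 (0.03 log units; within the scatter) and it stays within the scatter. For compound 3 the estimated value is 28000 nM with 12000 nM to 60000 nM as the expected range.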

Compound 3, half-maximal inhibitory concentration: > 100000 nM
Compound 3 ended at the assay's limit (the forecaster's own chance of this, stated with the estimate: 15%); middle value at least 3.5-fold (0.55 log units) away from the limit.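

In this assay compound 3 stands at a limit, not at a number: the limit of > 100000 nM in this assay, at which 1 of the 3 values shown sits. On the carbonyl carbon, the halogen swap stayed flat, with a 1.1-fold higher number from compound 1 to compound 2 (0.05 log units; within the scatter), but 3-(trifluoromethyl)phenyl brings an at least 3.3-fold higher number from compound 2 to compound 3 (0.52 log units; beyond the scatter) and an at least 3.7-fold higher number from compound 1 to compound 3 (0.56 log units; beyond the scatter). Going by these compounds, this position therefore does respond to the aryl group, in the direction of a weaker inhibitor, and the full size of both steps stays unknown past the limit.

Still open, on these data alone, is how 4-(trifluoromethyl)phenyl or 3-chlorophenyl would read, which would separate the group from its place on the ring. Also open, as far as these compounds go, is whether an amine on that ring would give a lower number than compound 1 and compound 2.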